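Cytotoxicity notes on three closely related compounds

A few compounds are considered here, and "the series" means these few. Any claim that something is new, unique, unknown or untested is made for them only; others in the source may bear on it.

compound 1 `COc1ccc(C2=C(c3cc(OC)c(OC)c(OC)c3)C(=O)CC2O[SiH2]C(C)(C)C)cc1OC`: > 100 ug/mL
compound 2 `COC(=O)c1cc(C2=C(c3cc(OC)c(OC)c(OC)c3)C(=O)CC2O[SiH2]C(C)(C)C)ccc1OC`: > 100 ug/mL

In an ADME assay on DU-145 cells (Homo sapiens) for cytotoxicity, read by MTT assay, with a stated time of 72 h (on this read-out higher numbers stand for weaker inhibition and lower numbers for stronger inhibition), compound 1 gives > 100 ug/mL, which is a limit of the assay and not a number. Compound 2 gives > 100 ug/mL in this assay, again a limit. Going by the values given here, both values therefore sit at the limit of > 100 ug/mL in this assay, at which 2 of the 2 values shown sit, and the single measured step, a step that the two limits leave unreadable from compound 1 to compound 2, cannot be read in size or direction. Compound 2 thus stands only at a limit on the numbers shown.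

Compound 3 `COCOc1cc(C2=C(c3cc(OC)c(OC)c(OC)c3)C(=O)CC2O[SiH2]C(C)(C)C)ccc1OC` differs from compound 2 as follows: methoxymethoxy in place of methoxycarbonyl on an aromatic carbon. No measured step bears on this particular change, and the one step shown is unreadable, so no step beyond the scatter is expected; the estimated step that the limit leaves unreadable from compound 2 to compound 3 is set near zero. Compound 3 is accordingly expected to give about 150 ug/mL in this assay, with a range from 50 ug/mL to 400 ug/mL, most likely reported again as a limit.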

Compound 3, half-maximal inhibitory concentration: 34 ug/mL
Beside the measured number, compound 3's estimate is 4.4-fold (0.64 log units) above it; measured number outside the range, below it.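

In this assay, the aromatic carbon ortho to a methoxy group proves to be a place where a change can be read, which the earlier pair could not show: methoxymethoxy in place of methoxycarbonyl gives an at least 2.9-fold lower number from compound 2 to compound 3 (0.46 log units; beyond the scatter). The entering and leaving groups have the same counts of heavy atoms and hydrogen-bond acceptors, so those counts alone do not separate the two compounds. Methoxymethoxy also differs from the methoxy group of compound 1 at this carbon, giving an at least 2.9-fold lower number from compound 1 to compound 3 (0.46 log units; beyond the scatter), and only compound 3 falls clear of the limit of the assay: the limit of > 100 ug/mL in this assay, at which 2 of the 3 values shown sit.

On these data alone, both steps start from a limit, so their full size stays open, and the step between compound 1 and compound 2 cannot be read. As far as these compounds go, whether a hydroxyl group, an amine or a longer chain such as ethoxymethoxy at this carbon would lower the number further also remains open.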